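The source may hold more compounds than are shown below. What is called first, only, known or untested is meant among the compounds shown, and "the series" means these compounds.

Compound 3 `CN1CCN(c2ccc(Nc3ncc4nc(Sc5ccccc5)n([C@H]5CC[C@H](O)CC5)c4n3)cc2)CC1` gives the lowest number of the three measured compounds in a functional assay on HCC827 cells (Homo sapiens) for antiproliferative activity, read by MTT assay, with a stated time of 72 h (a higher number here means a weaker inhibitor, a lower number a stronger inhibitor), with 42.6 nM, and its gaps to both neighbours lie beyond the scatter. Compound 2 `CN1CCN(c2ccc(Nc3ncc4nc(SCc5ccccc5)n(C5CCOCC5)c4n3)cc2)CC1` gives 107 nM in this assay, and compound 1 `CN1CCN(c2ccc(Nc3ncc4nc([S+]([O-])c5ccccc5)n(C5CCOCC5)c4n3)cc2)CC1` gives 411 nM. Among the compounds with values here, the only step between two compounds that differ in a single place, a 3.8-fold lower number from compound 1 to compound 2 (0.58 log units; beyond the scatter), concerns the group on the aromatic carbon and leaves the ring on the aromatic nitrogen untouched.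

Compound 4 `CN1CCN(c2ccc(Nc3ncc4nc(Sc5ccccc5)n(C5CCOCC5)c4n3)cc2)CC1` differs from compound 3 in exactly that ring: oxan-4-yl in place of 4-hydroxycyclohexyl on an aromatic nitrogen. Within the data shown here, no measured pair isolates this exchange. Compounds 1 and 2 both carry the oxan-4-yl ring, yet each also differs from compound 3 in the sulfur-bearing group, so what their values show cannot be split between the two changes. With nothing measured that bears directly on the ring exchange, the author expects the step of a 1.4-fold higher number from compound 3 to compound 4 (0.15 log units; within the scatter) to stay within the scatter, leaning if at all toward a somewhat higher number. Compound 4 is therefore estimated at 60 nM, with a range from 25 nM to 150 nM.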

Compound 4, half-maximal inhibitory concentration: 42.6 nM
Beside the measured number, compound 4's estimate is 1.4-fold (0.15 log units) above it; measured number inside the range.
By their numbers in this assay, from the lowest: compounds 3 and 4 (each within the scatter of the next); then compound 2; then compound 1.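

In this assay, within the data shown here, the exchange of 4-hydroxycyclohexyl for oxan-4-yl on the aromatic nitrogen gives no change at the digits printed from compound 3 to compound 4 (within the scatter) and so shows, for the first time, this position taken alone: with the phenylsulfanyl group held fixed, the ring can lose its hydrogen-bond donor and both defined stereocentres with no change in the number. Compound 4 also supplies the partner that compounds 1 and 2 lacked, so that with oxan-4-yl held fixed, phenyl in place of benzyl on the sulfur gives a 2.5-fold lower number from compound 2 to compound 4 (0.40 log units; beyond the scatter) and the change in the group on the aromatic carbon gives a 9.6-fold lower number from compound 1 to compound 4 (0.98 log units; beyond the scatter) in this series. Among these compounds, the steps beyond the scatter thus belong to the sulfur-bearing group, and the one step read at the aromatic nitrogen stays within the scatter.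

The compounds shown leave open whether a ring carrying an amine, such as piperidin-4-yl, or an open chain such as isopropyl would keep the number at this nitrogen. They also leave open whether the ring exchange would behave the same way with a benzyl group on the sulfur.

Nothing given here explains why the two rings match in this assay.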